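Ester to amide variation on the carbonyl carbon

A few compounds are considered here, and "the series" means these few. Any claim that something is new, unique, unknown or untested is made for them only; others in the source may bear on it.

compound 1 `CCOC(=O)c1sc2nc(SC)nc(-c3cccc(OC)c3)c2c1N`: 4.2%
compound 2 `COc1cccc(-c2nc(SC)nc3sc(C(=O)NCC#N)c(N)c23)c1`: 20.3%
compound 3 `COc1cccc(-c2nc(SC)nc3sc(C(=O)NN)c(N)c23)c1`: 8.5%

Compound 1, the ethyl ester, stands lowest of the three numbers in a functional assay on HEK293 cells for agonist activity at lutropin-choriogonadotropic hormone receptor (Homo sapiens), read by cAMP accumulation; on this read-out higher numbers stand for larger maximal responses and lower numbers for smaller maximal responses; compound 3 is nearest, within the scatter, and compound 2 furthest, beyond it. Compound 4 `COc1cccc(-c2nc(SC)nc3sc(C(=O)NCCO)c(N)c23)c1` has not yet been measured in this assay. It differs from compound 1 as follows: (2-hydroxyethyl)amino in place of ethoxy on a carbonyl carbon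

Among the compounds with values here, two measured steps bear on this change, both swapping the ethoxy on the carbonyl carbon for an amide-type nitrogen: a number 16.1 percentage points higher from compound 1 to compound 2 (beyond the scatter) and a number 4.3 percentage points higher from compound 1 to compound 3 (within the scatter). The contrast a number 11.8 percentage points lower from compound 2 to compound 3 (beyond the scatter) shows that the substituent on the amide nitrogen sets the size of the effect. Within the data shown here, no measured compound carries a (2-hydroxyethyl)amino group, so its outcome is read from these two steps alone: a modest rise above compound 1 is expected, probably between the two amide outcomes.

For compound 4 the expected maximal response is 12%, with a range of 4% to 24%. This estimate corresponds to a step of a number 7.8 percentage points higher from compound 1 to compound 4 (within the scatter), expected to be small to modest and upward.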

Compound 4, largest response reached (reported as efficacy), in percent of the reference or control that the assay uses: 20.5%
For compound 4 the middle estimate is 8.5 percentage points below the measured one, within the range that was stated.
By their numbers in this assay, from the lowest: compounds 1 and 3 (each within the scatter of the next); then compounds 2 and 4 (each within the scatter of the next).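

In this assay, the (2-hydroxyethyl)amino group gives a number 16.3 percentage points higher from compound 1 to compound 4 (beyond the scatter), so the rise over the ethyl ester on this carbonyl carbon is not confined to the cyanomethyl amide. Against the other amides, the change gives a number 12 percentage points higher from compound 3 to compound 4 (beyond the scatter), while a number 0.2 percentage points higher from compound 2 to compound 4 (within the scatter) shows that hydroxymethyl in place of cyano leaves the response within the scatter, so the nitrile is not required to reach this level, and compound 3 remains the amide that goes against the rise. No measurement available here accounts for these differences between the amide substituents.

As far as these compounds go, it remains open whether a longer chain, such as 3-hydroxypropyl, would hold this response on the amide nitrogen. A terminal amine or carboxylic acid on the same chain also remains untested by the compounds shown.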